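The compounds below may be only part of what the source reports. "The series", "measured", "known", "first", "only" and "open" are said of these compounds alone.

In an ADME assay on THP-1 cells (Homo sapiens) for cytotoxicity, read by MTT assay (on this read-out higher numbers stand for weaker inhibition and lower numbers for stronger inhibition), compound 1 `Fc1ccc(-c2nc(C(Cl)(Cl)Cl)nc3ccccc23)cc1` gives 125000 nM, and compound 2 `COc1ccc(-c2nc(C(Cl)(Cl)Cl)nc3ccccc23)cc1` gives 250000 nM. For the measured compounds named here, these are the only two exact numbers so far, and they cannot be told apart. Compound 3 `ClC(Cl)(Cl)c1nc(-c2ccc3ccccc3c2)c2ccccc2n1` reads > 500000 nM, which is a limit of the assay and not a number. This leaves (the limit of > 500000 nM in this assay, at which 1 of the 3 values shown sits).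

The next change leads to compound 4 `Cc1ccc(-c2nc(C(Cl)(Cl)Cl)nc3ccccc23)s1`, not yet measured, with 5-methylthiophen-2-yl in place of 4-fluorophenyl on an aromatic carbon of the shared core (5-methylthiophen-2-yl in place of 4-fluorophenyl on an aromatic carbon). Going by the values given here, only one measured step offers a direct guide: methoxy in place of fluoro gave a 2.0-fold higher number from compound 1 to compound 2 (0.30 log units; within the scatter). That step kept the aromatic ring and replaced only a group on it, so it is a loose guide to swapping the whole ring. It still gives no reason to expect a large shift. In this assay, the expected step is a 1.2-fold higher number from compound 1 to compound 4 (0.08 log units; within the scatter), so nothing beyond the scatter is anticipated. For compound 4 the estimated value is 150000 nM, with an expected range from 60000 nM to 400000 nM.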

Compound 4, half-maximal inhibitory concentration: 50000 nM
The estimate for compound 4 lay 3.0-fold (0.48 log units) above the measured number; measured number outside the range, below it.
By their numbers in this assay, from the lowest: compound 4; then compounds 1 and 2 (each within the scatter of the next). At a limit, above all of these: compound 3.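

In this assay, replacing the whole aromatic ring at this position, next to the ring nitrogen, gives a 2.5-fold lower number from compound 1 to compound 4 (0.40 log units; beyond the scatter), a modest step and the only one shown that lies beyond the scatter. The swap to 5-methylthiophen-2-yl changes the ring size, brings in a sulfur atom and replaces the fluoro group with a methyl group all at once, so the step cannot be assigned to any one of these changes. No measurement shown explains the shift.

Going by these compounds, it remains open whether an unsubstituted thiophen-2-yl ring would keep the step, which would separate the ring from its methyl group. Also open, on these data alone, is how an amine or a carboxylic acid on the ring at this position would read, as would replacing the trichloromethyl group with a methyl group.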